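Amide swap on the alkyne-linked core: from compound 1 to compound 4

The compounds below may be only part of what the source reports. "The series", "measured", "known", "first", "only" and "open" are said of these compounds alone.

Compound 1 `O=C(c1cccc(C#Cc2ccccc2Nc2ncnc3ccc(Cl)nc23)c1)N1CCOCC1` is known in an assay on isolated protein for inhibition of MAP kinase-interacting serine/threonine-protein kinase 1 (Homo sapiens), read by HTRF, in the presence of a further agent that is not named here (on this read-out higher numbers stand for weaker inhibition and lower numbers for stronger inhibition), only as a limit of the assay, > 10000 nM. Compound 2 `Cc1c(C(=O)N2CCOCC2)oc2ccc(Nc3ncnc4ccc(Cl)nc34)cc12` likewise reaches only the limit > 10000 nM in this assay. Compound 3 `COC(=O)c1oc2ccc(Nc3ncnc4ccc(Cl)nc34)cc2c1C` also stops at the limit > 10000 nM in this assay. The step from compound 2 to compound 3, a step that the two limits leave unreadable from compound 2 to compound 3, cannot be read, since all three results sit on one line, (the limit of > 10000 nM in this assay, at which 3 of the 3 values shown sit). Compound 4 `O=C(c1cccc(C#Cc2ccccc2Nc2ncnc3ccc(Cl)nc23)c1)N1CCNCC1` differs from compound 1 by piperazin-1-yl in place of morpholin-4-yl on a carbonyl carbon. Among the measured compounds shown here, no measured step resembles this change, and none of the readings separates one compound from another, so no step beyond the scatter is expected in this assay. Compound 4 is expected near 15000 nM, within 4000 nM to 60000 nM. The expected step from compound 1 to compound 4 is a step that the limit leaves unreadable from compound 1 to compound 4, most likely again reported only as a limit.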

Compound 4, half-maximal inhibitory concentration: > 10000 nM
Compound 4 gave a limit, no number (the forecaster's own chance of this, stated with the estimate: 80%); the middle value is on the limit's open side.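

No step can be read from compound 1 to compound 4, piperazin-1-yl in place of morpholin-4-yl, because both results are limits: the limit of > 10000 nM in this assay, at which 4 of the 4 values shown sit.

The compounds shown leave open whether this amide swap changes inhibition at all, and what any compound's actual potency is.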